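The source may report more compounds than this note shows. Statements on the series, on what has been measured and on what is new or still open speak of the compounds shown alone.

Of the compounds shown here, three built on one shared core have been tested in a functional assay on CHO.K1 cells for antagonist activity at prostaglandin D2 receptor 2 (Homo sapiens), read by GTPgammaS binding, with a stated time of 1 h; a higher number here means a weaker inhibitor, a lower number a stronger inhibitor. Compound 1 `Cc1c(Cc2cc(F)ccc2S(=O)(=O)c2ccccc2)c2c(n1CC(=O)O)CCNC2=O` gives 3.7 nM in this assay. Compound 2 `COc1cccc(S(=O)(=O)c2ccccc2)c1Cc1c2c(n(CC(=O)O)c1C)CCNC2=O` gives 4500 nM in this assay. Compound 3 `Cc1c(Cc2ccccc2S(=O)(=O)c2ccccc2F)c2c(n1CC(=O)O)CCNC2=O` gives 3.6 nM in this assay. Of these three numbers, compound 3 holds the lowest; its nearest neighbour is compound 1, whose number lies so close that the two cannot be told apart within the usual scatter, while compound 2 sits far away, well beyond the scatter.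

Compound 4 `Cc1c(Cc2ccccc2Cn2ccnn2)c2c(n1CC(=O)O)CCNC2=O` has not yet been measured. It differs from compound 3 in one place: (1H-1,2,3-triazol-1-yl)methyl in place of (2-fluorophenyl)sulfonyl on an aromatic carbon. For the measured compounds named here, no pair of measured compounds differs in just this way, so no measured step guides the expectation directly. Each of the three measured compounds carries a group of the kind that leaves here, and nothing in the data shows what happens once it is gone. A move to a smaller group with a different ring is therefore expected to cost potency: a step of a 33-fold higher number from compound 3 to compound 4 (1.52 log units; beyond the scatter) is estimated, upward in the number and beyond the scatter. Compound 4 is expected to give about 120 nM in this assay, with a plausible range from 12 nM to 1500 nM.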

Compound 4, half-maximal inhibitory concentration: 800 nM
Beside the measured number, compound 4's estimate is 6.7-fold (0.82 log units) below it; measured number inside the range.
By their numbers in this assay, from the lowest: compounds 3 and 1 (each within the scatter of the next); then compound 4; then compound 2.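

In this assay, putting (1H-1,2,3-triazol-1-yl)methyl in place of (2-fluorophenyl)sulfonyl on an aromatic carbon gives a 220-fold higher number from compound 3 to compound 4 (2.35 log units; beyond the scatter), a large step. For the compounds shown here, this is the first look at the series without a sulfonyl group at this place: the number is very sensitive to the change, yet compound 4 still gives a measurable 800 nM in this assay, so inhibition is weakened but not lost. Nothing measured here speaks to the reason for this loss of potency.

The change replaces two things at once, the sulfonyl link with a methylene link and the fluorinated benzene ring with a triazole ring, and the compounds shown cannot say how much of the step belongs to each. Going by these compounds, a 2-fluorobenzyl group at the same place, which keeps the ring that leaves on the link that enters, would help to separate the two, and how it would behave remains open.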